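This account rests on a few compounds, and the source may have more. Where it says the series, first, only, none or still open, it means among the compounds named here.

Measured compounds, all in a functional assay (aorta) with Oryctolagus cuniculus as the target (a higher number here means weaker binding, a lower number tighter binding), as follows
compound 1 `COc1cc(OCCCN2CCC(C(c3ccc(F)cc3)c3ccc(F)cc3)CC2)ccc1C(C)=O` at 3.16 nM
compound 2 `Fc1ccc(C(c2ccc(F)cc2)C2CCN(CCCOc3ccc(Cl)cc3)CC2)cc1` at 2 nM
compound 3 `COc1ccccc1OCCCN1CCC(C(c2ccc(F)cc2)c2ccc(F)cc2)CC1` at 2.51 nM

Compound 3 sits within the scatter of both others, as the steps of a 1.3-fold lower number from compound 1 to compound 3 (0.10 log units; within the scatter) and a 1.3-fold higher number from compound 2 to compound 3 (0.10 log units; within the scatter) show. The remaining step of a 1.6-fold lower number from compound 1 to compound 2 (0.20 log units; within the scatter) also stays within it. Compound 4 `O=S(=O)(CCCN1CCC(C(c2ccc(F)cc2)c2ccc(F)cc2)CC1)c1ccccc1` brings the change phenylsulfonyl in place of 2-methoxyphenoxy on a saturated chain carbon, three bonds along the chain from an amine nitrogen in a ring and so carries phenylsulfonyl in place of 2-methoxyphenoxy. Among the compounds with values here, the measured steps only exchange the aromatic group on the oxygen, and no measured compound carries a sulfonyl, so they bear on this change only loosely. A modest move towards a higher number is expected, with wide uncertainty. The estimated step reads a 2.4-fold higher number from compound 3 to compound 4 (0.38 log units; beyond the scatter) on this view. For compound 4 the estimated value is 6 nM within a range of 1.5 nM to 25 nM overall.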

Compound 4, dissociation constant: 20 nM
The estimate for compound 4 lay 3.3-fold (0.52 log units) below the measured number; low and high end bracket the measured number.
By their numbers in this assay, from the lowest: compounds 2, 3 and 1 (each within the scatter of the next); then compound 4.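

In this assay the three aromatic groups on the oxygen stayed within the scatter of one another, but phenylsulfonyl on the same chain carbon gives clear steps beyond it (an 8.0-fold higher number from compound 3 to compound 4 (0.90 log units; beyond the scatter); a 10-fold higher number from compound 2 to compound 4 (1.00 log units; beyond the scatter); a 6.3-fold higher number from compound 1 to compound 4 (0.80 log units; beyond the scatter)). This position therefore tolerates changes to the aromatic group more readily than this exchange, although the ring substituents change along with the sulfonyl. Nothing available explains the loss.

Going by these compounds, it stays open whether a plain phenoxy or a phenylthio group would keep the low numbers, and whether a longer chain would recover them with the phenylsulfonyl in place.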